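Adding a methoxy group to compound 2

A few compounds are considered here, and "the series" means these few. Any claim that something is new, unique, unknown or untested is made for them only; others in the source may bear on it.

Compound 1 `COc1ccc(Cn2nnc3c(C(N)=O)ncn3c2=O)cc1`: > 50000 nM (a limit)
Compound 2 `C[C@H](c1ccccc1)n1nnc2c(C(N)=O)ncn2c1=O`: 32700 nM
Compound 3 `C[C@@H](c1ccccc1)n1nnc2c(C(N)=O)ncn2c1=O`: 34700 nM

Among the measured compounds shown here, in a functional assay on SNB-19 cells (Homo sapiens) for inhibition, read by MTT assay, with a stated time of 7 days (a higher number here means a weaker inhibitor of growth, a lower number a stronger inhibitor of growth), compound 2 gives 32700 nM, one of only two true numbers in this set. The other lies very close, with a 1.1-fold higher number from compound 2 to compound 3 (0.03 log units; within the scatter). This step reflects (the fact that compounds 2 and 3 differ only in the configuration as drawn), so it shows that configuration changes little here but tells nothing about a new group.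

The next compound is compound 4 `COc1ccc([C@@H](C)n2nnc3c(C(N)=O)ncn3c2=O)cc1`, which differs from compound 2 by one change: methoxy in place of hydrogen on an aromatic carbon.

For the measured compounds named here, no measured step isolates this change. The nearest clue is compound 1, which also carries a methoxy group. Its > 50000 nM is a limit and not a number. This is weak evidence, but it gives no reason to expect stronger growth inhibition. In this assay, no step beyond the scatter is therefore expected, with any drift towards a higher number. The expected change is a 1.2-fold higher number from compound 2 to compound 4 (0.09 log units; within the scatter). For compound 4, the estimated value is 40000 nM, with an expected range of 20000 nM to 70000 nM.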

Compound 4, concentration for 50% growth inhibition: > 50000 nM
Compound 4: a limit, no number; the forecaster's own chance of this, stated with the estimate: 35%; at least 1.2-fold (0.09 log units) between middle value and limit.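

Putting methoxy in place of hydrogen on the aromatic carbon para to a large group gives an at least 1.5-fold higher number from compound 2 to compound 4 (0.18 log units; that floor lies within the scatter), so this change shows no sign of stronger growth inhibition at this position. In this assay, from the compounds shown here alone, compound 4 gives > 50000 nM, which is a limit and not a number, so the true size of the step stays unknown. The step from compound 1 to compound 4 cannot be read, as both values are limits.

Going by these compounds, whether an amine or a single fluorine atom at this same position would shift growth inhibition beyond the scatter stays open. Also open, on these data alone, is how the methoxy compound with the opposite configuration at the chain carbon would behave in this assay.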